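This account rests on a few compounds, and the source may have more. Where it says the series, first, only, none or still open, it means among the compounds named here.

Compound 1, `Fc1ccc(Cn2cc(CSC(=S)N3CCNCC3)nn2)cc1`: in a functional assay on PC-3 cells (Homo sapiens) for inhibition, read by MTT assay, with a stated time of 72 h (on this read-out lower numbers stand for stronger inhibition and higher numbers for weaker inhibition), compound 1 gives > 128000 nM, which is a limit of the assay and not a number.
Compound 2, `S=C(SCc1cn(Cc2ccc(Cl)c(Cl)c2)nn1)N1CCNCC1`: in this assay compound 2 gives "not determined" (no result reported).
Compound 3, `S=C(SCc1cn(Cc2ccc(Cl)cc2)nn1)N1CCNCC1`: in this assay compound 3 gives > 128000 nM, again a limit of the assay rather than a number.

Compound 3 therefore stands at the limit of > 128000 nM in this assay, at which 2 of the 3 values shown sit, and no inhibition could be placed for it within the tested range. Within the data shown here, the one single-point change among the measured compounds, a step that the two limits leave unreadable from compound 1 to compound 3, is between two limits and yields no readable size. The next change, from compound 3 to compound 4 (`COc1ccc(Cn2cc(CSC(=S)N3CCNCC3)nn2)cc1`), is methoxy in place of chloro on an aromatic carbon. Among the measured compounds shown here, no measured step bears on this change in a readable way, since the only one available sits between two limits and compound 2 has no result.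

With nothing to read from, the expectation for compound 4 is that a number no higher from compound 3 to compound 4 (the limit leaves the size open) in this assay will again show no measurable inhibition. The estimate for compound 4 in this assay is 128000 nM, with a range from 25000 nM to 600000 nM, and most likely the assay will report only a limit.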

Compound 4, half-maximal inhibitory concentration: > 128000 nM
Compound 4: only a limit was reported (the forecaster's own chance of this, stated with the estimate: 80%); the middle value sits exactly at the limit.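

In this assay compound 4 gives > 128000 nM, which is a limit of the assay and not a number. Among these compounds, compound 1, compound 3 and compound 4 all end at limits, so no step among them can be read. The compounds shown leave open how fluoro, chloro and methoxy compare, and whether any group at this aromatic carbon brings inhibition into a readable range: the limit of > 128000 nM in this assay, at which 3 of the 4 values shown sit.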